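A few compounds are considered here, and "the series" means these few. Any claim that something is new, unique, unknown or untested is made for them only; others in the source may bear on it.

In a functional assay (aorta, strain Wistar) for inhibition, with Rattus norvegicus as the target (on this read-out higher numbers stand for weaker inhibition and lower numbers for stronger inhibition), compound 1 `CCCCc1nc(Cl)c(COC(=O)CCCCO[N+](=O)[O-])n1Cc1ccc(-c2ccccc2-c2nn[nH]n2)cc1` gives 851 nM, the second highest of three numbers, with compound 2 `CCCCc1nc(Cl)c(COC(=O)c2cccc(CO[N+](=O)[O-])c2)n1Cc1ccc(-c2ccccc2-c2nn[nH]n2)cc1` at 275 nM and compound 3 `CCCCc1nc(Cl)c(COC(=O)c2ccc(C(C)O[N+](=O)[O-])cc2)n1Cc1ccc(-c2ccccc2-c2nn[nH]n2)cc1` at 7760 nM. Compound 4 `CCCCc1nc(Cl)c(CO[N+](=O)[O-])n1Cc1ccc(-c2ccccc2-c2nn[nH]n2)cc1` is still unmeasured. It differs from compound 1 by nitro in place of (4-(nitrooxy)butyl)carbonyl on an oxygen on a saturated carbon. The measured steps only exchange the group on the carbonyl carbon: a 3.1-fold lower number from compound 1 to compound 2 (0.49 log units; beyond the scatter), a 9.1-fold higher number from compound 1 to compound 3 (0.96 log units; beyond the scatter) and a 28-fold higher number from compound 2 to compound 3 (1.45 log units; beyond the scatter). They run both ways, and none removes the carbonyl, so they show how far the number can move but give no direction. The expected change is therefore none beyond the scatter, an estimated 1.1-fold lower number from compound 1 to compound 4 (0.03 log units; within the scatter). For compound 4 the estimate is 800 nM, with an expected range from 150 nM to 4500 nM.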

Compound 4, half-maximal inhibitory concentration: 15100 nM
For compound 4 the middle estimate is 19-fold (1.28 log units) below the measured one, outside the stated range (above it).
By their numbers in this assay, from the lowest: compound 2; then compound 1; then compounds 3 and 4 (each within the scatter of the next).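

Replacing (4-(nitrooxy)butyl)carbonyl with nitro on the oxygen on a saturated carbon gives, in this assay, an 18-fold higher number from compound 1 to compound 4 (1.25 log units; beyond the scatter), which means weaker inhibition. This is the first change shown that removes the carbonyl, and it gives the position a direction: here, losing the whole group costs inhibition. No data shown account for this loss.

Because the carbonyl and the chain leave together, their contributions remain unseparated. A 4-(nitrooxy)butyl ether on the same oxygen, or a simple hydroxyl group there, would leave open how each part contributes.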